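The source may hold more compounds than are shown below. What is called first, only, known or untested is meant among the compounds shown, and "the series" means these compounds.

Working notes on the series. Compound 1 `FC(F)(F)c1ccc(Cn2c(Br)nc3cc(Cl)c(Cl)cc32)cc1` carries a trifluoromethyl on its benzyl ring. In a functional assay on CEM-SS cells (Homo sapiens) for cytotoxicity (on this read-out higher numbers stand for weaker inhibition and lower numbers for stronger inhibition), compound 1 gives > 100000 nM, which is a limit of the assay and not a number. Compound 2 `FC(F)(F)c1cccc(Cn2c(Br)nc3cc(Cl)c(Cl)cc32)c1` has the same atoms as compound 1 joined differently; the difference between the two cores is not broken down here. In this assay compound 2 gives > 100000 nM, again a limit and not a number. Compound 3 `O=[N+]([O-])c1ccc(Cn2c(Br)nc3cc(Cl)c(Cl)cc32)cc1` differs from compound 1 by nitro in place of trifluoromethyl on an aromatic carbon. In this assay compound 3 gives > 100000 nM, also a limit. The step that the two limits leave unreadable from compound 1 to compound 3 cannot be sized because of the limit of > 100000 nM in this assay, at which 3 of the 3 values shown sit. Going by the values given here, no value in this assay so far falls below that limit, so no ordering among compound 1, compound 2 and compound 3 can be read.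

Compound 4 `O=[N+]([O-])c1cccc(Cn2c(Br)nc3cc(Cl)c(Cl)cc32)c1`, not yet measured, differs from compound 2 by nitro in place of trifluoromethyl on an aromatic carbon. This is the same kind of change as from compound 1 to compound 3, though not the same: in compound 3 the nitro sits para to a large group, in compound 4 it sits meta to a large group. The step from compound 2 to compound 4 in this assay is expected to be a number no higher from compound 2 to compound 4 (the limit leaves the size open), an expectation that rests on the limit of > 100000 nM in this assay, at which 3 of the 3 values shown sit, and on the unreadable step that the two limits leave unreadable from compound 1 to compound 3. Compound 4 is expected at 100000 nM, with a range from 40000 nM to 250000 nM, and most likely it too will come back only as a limit.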

Compound 4, half-maximal inhibitory concentration: > 100000 nM
Compound 4: a limit, no number; the forecaster's own chance of this, stated with the estimate: 85%; the middle value sits exactly at the limit.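

Compound 4 also comes back only as a limit and not a number, so no step can be read from compound 2 to compound 4 in this assay: the limit of > 100000 nM in this assay, at which 4 of the 4 values shown sit.

The compounds shown leave open whether nitro in place of trifluoromethyl on an aromatic carbon shifts the read-out at all, and where any of the four compounds would fall as a number in this assay.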